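Working notes: octyl in place of 4-bromophenyl, compound 4

This account rests on a few compounds, and the source may have more. Where it says the series, first, only, none or still open, it means among the compounds named here.

Measured compounds:
compound 1 `CC(=O)OCC(CCn1cc(C#Cc2cc(F)cc(F)c2)c(=O)n(C(=O)c2ccccc2)c1=O)COC(C)=O` — in a functional assay on SW-620 cells (Homo sapiens) for antiproliferative activity, read by MTT assay, with a stated time of 72 h (on this read-out lower numbers stand for stronger inhibition and higher numbers for weaker inhibition), compound 1 gives > 100000 nM, a limit of the assay.
compound 2 `O=c1[nH]c(=O)n(CCC(CO)CO)cc1C#Cc1ccc(Br)cc1` — in this assay compound 2 gives > 100000 nM, again only a limit.
compound 3 `CCCCCc1ccc(C#Cc2cn(CCC(CO)CO)c(=O)[nH]c2=O)cc1` — in this assay compound 3 gives > 100000 nM, also a limit.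

Compound 2 therefore stands nowhere on a numerical scale in this assay; only a limit is known for it, as for the two other compounds shown. Going by the values given here, the one single-site step among the measured compounds, a step that the two limits leave unreadable from compound 2 to compound 3, cannot be read because both ends are limits, as summarised by the limit of > 100000 nM in this assay, at which 3 of the 3 values shown sit.

Compound 4 `CCCCCCCCC#Cc1cn(CCC(CO)CO)c(=O)[nH]c1=O` differs from compound 2 in one place: octyl in place of 4-bromophenyl on a triple-bonded carbon. Among the compounds with values here, no measured step bears on an octyl chain in this position, and the only comparable change, the bromo-to-pentyl step, gives no readable size. No step beyond the scatter can be expected in either direction in this assay; a further limit is the most likely outcome.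

Compound 4 is therefore estimated at 100000 nM in this assay, within 30000 nM to 300000 nM. The step from compound 2 to compound 4 is expected to be a number no higher from compound 2 to compound 4 (the limit leaves the size open), essentially none that can be seen.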

Compound 4, half-maximal inhibitory concentration: > 100000 nM
Compound 4 was reported as a limit; the forecaster's own chance of this, stated with the estimate: 80%; the middle value sits exactly at the limit.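

No new step can be read between compound 2 and compound 4, because both are reported only as limits: the limit of > 100000 nM in this assay, at which 4 of the 4 values shown sit.

The compounds shown leave open whether any group on the triple-bonded carbon gives a numerical value in this assay, and how far such groups differ.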